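The compounds below may be only part of what the source reports. "The series", "measured", "known", "first", "only" and "open" are said of these compounds alone.

Compound 1 `COc1ccc(/C=C2\CCC/C(=C\c3ccccc3[N+](=O)[O-])C2=O)cc1`: 7450 nM
Compound 2 `O=C1/C(=C/c2ccc(Cl)cc2)CCC/C1=C\c1ccc([N+](=O)[O-])cc1`: 8180 nM

In a functional assay on CCRF-CEM cells (Homo sapiens) for cytotoxicity, with a stated time of 72 h (a higher number here means a weaker inhibitor, a lower number a stronger inhibitor), compound 1 gives 7450 nM, and compound 2 gives 8180 nM; the two numbers lie within the scatter of each other, so neither can be set above the other. Compound 3 `O=C1/C(=C/c2ccccc2)CCC/C1=C\c1ccccc1[N+](=O)[O-]` differs from compound 1 by hydrogen in place of methoxy on an aromatic carbon. Within the data shown here, no measured pair shows what this change does here, so the expectation rests on the two values alone. The step of a 1.2-fold higher number from compound 1 to compound 3 (0.08 log units; within the scatter) is expected to stay small, in no clear direction, and not beyond the scatter. Compound 3 is therefore estimated at 9000 nM, with a range from 3000 nM to 27000 nM.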

Compound 3, half-maximal inhibitory concentration: 925 nM
Compound 3: middle estimate off by 9.7-fold (0.99 log units), on the high side; the whole stated range lies above it.
By their numbers in this assay, from the lowest: compound 3; then compounds 1 and 2 (each within the scatter of the next).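

In this assay, among these compounds, putting hydrogen in place of methoxy gives an 8.1-fold lower number from compound 1 to compound 3 (0.91 log units; beyond the scatter) and so shows that this place on the ring is not indifferent, as the close values of the earlier compounds could not show. The methoxy group here goes with the weaker inhibitor, though this rests on a single pair. No measurement at hand explains the step. Going by these compounds, whether a hydroxyl group, a fluorine atom or an amine at this place would match hydrogen or methoxy remains open, as does whether the same change acts alike on the core of compound 2.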